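The source may hold more compounds than are shown below. What is called first, only, known or untested is meant among the compounds shown, and "the series" means these compounds.

Three compounds share one core and differ only in what sits on a sulfonamide nitrogen. Compound 1, `NS(=O)(=O)c1ccc(NC2=NC(=O)/C(=C\c3coc4ccccc4c3=O)S2)cc1`, carries a hydrogen there, and in a functional assay on A549 cells (Homo sapiens) for cytotoxicity, read by sulforhodamine B assay, with a stated time of 72 h (on this read-out lower numbers stand for stronger inhibition and higher numbers for weaker inhibition), compound 1 gives 2230 nM. Compound 2, `O=C1N=C(Nc2ccc(S(=O)(=O)Nc3nccs3)cc2)S/C1=C/c1coc2ccccc2c1=O`, carries a 1,3-thiazol-2-yl group on that nitrogen; in this assay compound 2 reaches the limit of the assay, > 100000 nM, which is not a number. Compound 3, `Cc1cc(C)nc(NS(=O)(=O)c2ccc(NC3=NC(=O)/C(=C\c4coc5ccccc5c4=O)S3)cc2)n1`, carries a 4,6-dimethylpyrimidin-2-yl group on the same nitrogen, and compound 3 also stands at the limit, > 100000 nM. Compound 3 thus stands at the weak end of what is shown: the step of an at least 44-fold higher number from compound 1 to compound 3 (1.65 log units; beyond the scatter) runs the same way as an at least 44-fold higher number from compound 1 to compound 2 (1.65 log units; beyond the scatter), while a step that the two limits leave unreadable from compound 2 to compound 3 cannot be read, since both values sit at the limit of > 100000 nM in this assay, at which 2 of the 3 values shown sit.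

Compound 4, `Cc1cc(NS(=O)(=O)c2ccc(NC3=NC(=O)/C(=C\c4coc5ccccc5c4=O)S3)cc2)no1`, makes a further change of the same kind: 5-methyl-1,2-oxazol-3-yl in place of 4,6-dimethylpyrimidin-2-yl on a sulfonamide nitrogen. Both measured steps that put a ring on this nitrogen were large and ran towards weaker inhibition, and nothing shown points the other way. Compound 4 is therefore expected to stay near the limit, with a step of an at least 1.2-fold lower number from compound 3 to compound 4 (0.09 log units; that floor lies within the scatter) that is not expected to exceed the scatter. The estimate for compound 4 is 80000 nM, in a range from 10000 nM to 300000 nM.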

Compound 4, half-maximal inhibitory concentration: > 100000 nM
Compound 4: only a limit was reported (the forecaster's own chance of this, stated with the estimate: 75%); at least 1.2-fold (0.09 log units) between middle value and limit.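

In this assay compound 4 gives > 100000 nM, which is a limit of the assay and not a number. A five-membered ring holding oxygen and nitrogen on the sulfonamide nitrogen thus goes the same way as the two rings before it, with an at least 44-fold higher number from compound 1 to compound 4 (1.65 log units; beyond the scatter), so all three ring-bearing compounds shown, compound 2, compound 3 and compound 4, lie on the weak side of compound 1, and none goes against this. The steps among compound 2, compound 3 and compound 4 cannot be read, so the change from 4,6-dimethylpyrimidin-2-yl to 5-methyl-1,2-oxazol-3-yl gives no ranking of these rings, and the series now has only one measured number: the limit of > 100000 nM in this assay, at which 3 of the 4 values shown sit.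

On these data alone, it remains open whether a ring is needed for this weakening at all, since a single methyl or an acetyl group on this nitrogen could show whether anything other than hydrogen has the same outcome. As far as these compounds go, it is also open whether a ring without hetero atoms, such as phenyl, or a saturated ring, such as piperidine, would give a value that can be read as a number rather than a limit.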